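A few compounds are considered here, and "the series" means these few. Any claim that something is new, unique, unknown or untested is made for them only; others in the source may bear on it.

Measured in an ADME assay on WI-38 cells (Homo sapiens) for cytotoxicity, read by MTT assay, with a stated time of 3 days; a higher number here means a weaker inhibitor, a lower number a stronger inhibitor:
compound 1 `O=C1c2ccccc2C(=O)N1C/C=C\Cn1cc(C#Cc2ccc(Br)cc2)c(=O)[nH]c1=O`: 47000 nM
compound 2 `CCCCCC#Cc1cn(C/C=C/CN2C(=O)c3ccccc3C2=O)c(=O)[nH]c1=O`: 40000 nM
compound 3 `CCCCC#Cc1cn(C/C=C\CN2C(=O)c3ccccc3C2=O)c(=O)[nH]c1=O`: 28000 nM

Compound 2, at 40000 nM, lies within the scatter of both other compounds. Compound 4 `O=C1c2ccccc2C(=O)N1C/C=C/Cn1cc(C#CCCc2ccccc2)c(=O)[nH]c1=O` differs from it by phenyl in place of propyl on a saturated chain carbon, two bonds along the chain from a triple-bonded carbon. Among the compounds with values here, only one measured step bears on this change, though it exchanges a chain and a ring at a different place: a 1.7-fold lower number from compound 1 to compound 3 (0.22 log units; within the scatter). It stays within the scatter, so no step beyond the scatter is expected in this assay. The expected step is a 1.1-fold lower number from compound 2 to compound 4 (0.02 log units; within the scatter). Compound 4 is estimated at 38000 nM, with an expected range of 20000 nM to 75000 nM.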

Compound 4, half-maximal inhibitory concentration: 31000 nM
Compound 4: middle estimate off by 1.2-fold (0.09 log units), on the high side; the range from low to high includes it.
By their numbers in this assay, from the lowest: compounds 3, 4, 2 and 1 (each within the scatter of the next).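

In this assay putting phenyl in place of propyl on a saturated chain carbon, two bonds along the chain from a triple-bonded carbon, gives a 1.3-fold lower number from compound 2 to compound 4 (0.11 log units; within the scatter) and so stays within the scatter. The earlier compounds shown here showed an exchange of chain and ring only on a triple-bonded carbon itself; this step shows that the saturated chain carbon also takes a ring with no step beyond the scatter. No evidence shown here explains this result. From the compounds shown here alone, whether an amine or a carboxylic acid at this place would give a step beyond the scatter in this assay remains open.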